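The source may report more compounds than this note shows. Statements on the series, on what has been measured and on what is new or still open speak of the compounds shown alone.

Measured so far:
compound 1 `O=C(NCCCCc1ccccc1)n1c(=O)oc2cc(C3CCOCC3)ccc21`, 68 nM in an assay on HEK293 cells for inhibition of acid ceramidase (Homo sapiens), read by fluorescence, with stated times of 10 min and 3 h; on this read-out lower numbers stand for stronger inhibition and higher numbers for weaker inhibition
compound 2 `CN1CCC(c2ccc3c(c2)oc(=O)n3C(=O)NCCCCc2ccc(F)cc2)CC1`, 94 nM in this assay

Compound 1 gives the lowest of the two numbers in this assay, but compound 2 lies within the usual scatter of it, so no order is claimed. Compound 3 `CN1CCN(c2ccc3c(c2)oc(=O)n3C(=O)NCCCCc2ccccc2)CC1` keeps the rest of compound 1 and carries 4-methylpiperazin-1-yl in place of oxan-4-yl on an aromatic carbon. Within the data shown here, no step between two measured compounds covers this exchange on its own. Compound 2, which also carries a methyl-bearing nitrogen ring, gives a number close to that of compound 1, so in this assay no step beyond the scatter is expected for compound 3, with a slight lean toward a higher number. The estimate for compound 3 is 90 nM, range 35 nM to 250 nM, an expected step of a 1.3-fold higher number from compound 1 to compound 3 (0.12 log units; within the scatter).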

Compound 3, half-maximal inhibitory concentration: 116 nM
Estimate against measurement, compound 3: 1.3-fold (0.11 log units) below; low and high end bracket the measured number.
By their numbers in this assay, from the lowest: compounds 1, 2 and 3 (each within the scatter of the next).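

In this assay, among these compounds, 4-methylpiperazin-1-yl in place of oxan-4-yl on this aromatic carbon gives a 1.7-fold higher number from compound 1 to compound 3 (0.23 log units; within the scatter), the first step at this position with the rest of the molecule unchanged. This six-membered ring can therefore carry two nitrogens, one bearing a methyl, instead of one oxygen without a step beyond the scatter. No available data bear on a cause for this result.

Going by these compounds, whether a carboxylic acid or an open-chain amine on this carbon would give a step beyond the scatter remains open. Also open, on these data alone, is whether this exchange behaves the same with a longer chain elsewhere in the molecule.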